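Quinoline urea series: aryl urea replacing semicarbazide

The source may hold more compounds than are shown below. What is called first, only, known or untested is meant among the compounds shown, and "the series" means these compounds.

Two members of the shared core have been measured. Compound 1 `COc1cc(NC(C)CCCNC(=O)Nc2ccc(O)cc2)c2ncccc2c1` gives 21000 nM in a functional assay on L1210 cells (Mus musculus) for inhibition, read by MTT assay, with a stated time of 72 h; a lower number here means a stronger inhibitor, a higher number a weaker inhibitor. Among the compounds with values here, compound 2 `COc1cc(NC(C)CCCNC(=O)NNC(=O)Nc2ccc(F)cc2)c2ncccc2c1`, carrying the semicarbazide arm, gives 104000 nM in this assay; on the two numbers so far compound 2 stands highest, with compound 1 the nearest. Within the data shown here, the one measured step, a 5.0-fold higher number from compound 1 to compound 2 (0.69 log units; beyond the scatter), links these two.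

Compound 3 `COc1cc(NC(C)CCCNC(=O)Nc2cccc(C(F)(F)F)c2)c2ncccc2c1` is not yet measured. Its difference from compound 2 is 3-(trifluoromethyl)phenyl in place of ((4-fluorophenyl)carbamoyl)amino on an amide-type nitrogen. This brings an aromatic ring straight back onto the amide-type nitrogen, as in compound 1, so the step from compound 1 to compound 2 is the only one that bears on it, and the expectation is that it is roughly undone. In this assay compound 3 is therefore expected to give 25000 nM, within 8000 nM to 80000 nM. The expected step is a 4.2-fold lower number from compound 2 to compound 3 (0.62 log units; beyond the scatter); whether the trifluoromethyl ring lands exactly where the hydroxyphenyl did cannot be told from two points.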

Compound 3, half-maximal inhibitory concentration: 9200 nM
Compound 3: the middle estimate sits 2.7-fold (0.43 log units) above what was measured, within the range that was stated.
By their numbers in this assay, from the lowest: compound 3; then compound 1; then compound 2.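

In this assay, the 3-(trifluoromethyl)phenyl on the amide-type nitrogen gives an 11-fold lower number from compound 2 to compound 3 (1.05 log units; beyond the scatter), so leaving the semicarbazide arm for this aryl urea moves the number further than the earlier step suggested. The two aryl ureas also do not coincide: a 2.3-fold lower number from compound 1 to compound 3 (0.36 log units; beyond the scatter) shows that the ring placed on this nitrogen matters, not merely having a ring there. Nothing at hand explains either step.

The 4-hydroxyphenyl and 3-(trifluoromethyl)phenyl rings differ in both the group carried and where it is carried, so these compounds cannot separate those two changes. From the compounds shown here alone, how a plain phenyl, a 4-(trifluoromethyl)phenyl or a ring bearing a nitrile or carboxylic acid would compare on this nitrogen remains open.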